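Triazole-fused oxadiazoles: aryl for isobutyl at the oxadiazole

A few compounds are considered here, and "the series" means these few. Any claim that something is new, unique, unknown or untested is made for them only; others in the source may bear on it.

Measured so far:
- compound 1, `Fc1ccc(-c2nc(-c3ccc4c(c3)nnn4C3CCCC3)no2)cc1`: 51%
- compound 2, `CN1CCC(n2nnc3c2CCC(c2nc(-c4ccc(F)cc4)no2)C3)CC1`: 91%
- compound 3, `CC(C)Cc1noc(C2CCc3c(nnn3C(C)(C)C)C2)n1`: 66%

All three numbers come from a functional assay on U2OS cells with metabotropic glutamate receptor 5 (Homo sapiens) as the target, read by calcium flux; on this read-out higher numbers stand for larger maximal responses and lower numbers for smaller maximal responses. Compound 3 stands second highest of the three. Its nearest neighbour on the numbers is compound 1, which in this assay gives 51%, a gap beyond the scatter; the furthest is compound 2, which in this assay gives 91%, also beyond the scatter. No pair of these compounds differs in one place only, so the three numbers are read as they stand and no step is derived from them.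

Compound 4, `CC(C)(C)n1nnc2c1CCC(c1nc(-c3ccc(C#N)cc3)no1)C2`, is not yet measured. It differs from compound 3 in one place: 4-cyanophenyl in place of isobutyl on an aromatic carbon. The group that enters is the 4-cyanophenyl, an aromatic ring with a nitrile, where compounds 1 and 2 carry 4-fluorophenyl on their own cores. Those two compounds bracket a wide range, one below and one above compound 3, and their cores differ from that of compound 3, so no clean direction follows from them.

The step of a number 6 percentage points higher from compound 3 to compound 4 (within the scatter) is therefore expected to stay within the scatter, with a wide band to either side. For compound 4 in this assay the estimate is 72%, expected between 45% and 95%.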

Compound 4, largest response reached (reported as percent of maximum), in percent of the reference or control that the assay uses: 87%
The estimate for compound 4 lay 15 percentage points below the measured number; the measured number falls inside the stated range.
By their numbers in this assay, from the lowest: compound 1; then compound 3; then compounds 4 and 2 (each within the scatter of the next).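

In this assay, this is the only comparison among the compounds shown that changes one place alone, and it gives a number 21 percentage points higher from compound 3 to compound 4 (beyond the scatter). The aromatic carbon between two ring nitrogen atoms on the oxadiazole therefore accepts the 4-cyanophenyl, with its 8 heavy atoms and six-membered aromatic ring, in place of the 4 heavy atoms of isobutyl, and the maximal response does not fall but rises beyond the scatter. No measurement shown bears on the reason for this rise, so the step stands as an observation about this one pair.

Within the data shown here, the single step cannot separate the contribution of the aromatic ring from that of the nitrile, and an unsubstituted phenyl at the same carbon, with the rest of compound 4 unchanged, would address that question directly. Going by these compounds, it also remains open whether the rise extends to other replacements at this carbon, such as a longer alkyl chain or a phenyl ring bearing a carboxylic acid in place of the nitrile, or whether it holds on a different core.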